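Moving a Trifluoromethyl Group on a Sulfonyl Linker

A few compounds are considered here, and "the series" means these few. Any claim that something is new, unique, unknown or untested is made for them only; others in the source may bear on it.

Compound 1, `CC(O)(CSc1ccc(C(F)(F)F)cc1)C(=O)Nc1cccc(S(F)(F)(F)(F)F)c1`: 26900 nM
Compound 2, `CC(O)(CSc1cccc(C(F)(F)F)c1)C(=O)Nc1cccc(S(F)(F)(F)(F)F)c1`: 12900 nM
Compound 3, `CC(O)(CS(=O)(=O)c1ccc(C(F)(F)F)cc1)C(=O)Nc1ccc(S(F)(F)(F)(F)F)cc1`: 28900 nM

These three numbers come from a functional assay on CWR22R cells (Homo sapiens) for antiproliferative activity, read by propidium iodide staining, with a stated time of 96 h; on this read-out lower numbers stand for stronger inhibition and higher numbers for weaker inhibition. Compound 1 and compound 2 share a core and differ only in the change (3-(trifluoromethyl)phenyl in place of 4-(trifluoromethyl)phenyl on a sulfur). That single change gave a 2.1-fold lower number from compound 1 to compound 2 (0.32 log units; beyond the scatter), a modest gain in potency.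

Compound 3 carries a different core; how its core differs from that of compound 1 is not broken down here. Compound 3 shows the highest number of the three, though its gap to compound 1 lies within the usual scatter, while its gap to compound 2 lies beyond it.

Compound 4, `CC(O)(CS(=O)(=O)c1cccc(C(F)(F)F)c1)C(=O)Nc1ccc(S(F)(F)(F)(F)F)cc1`, has not yet been measured in this assay. It differs from compound 3 by 3-(trifluoromethyl)phenyl in place of 4-(trifluoromethyl)phenyl on a sulfonyl sulfur. The surroundings of the change are not identical to those in the first pair: in compound 4 the group sits on a sulfonyl sulfur whose other neighbours are a saturated chain carbon, whereas in compound 2 it sits on a sulfur whose other neighbours are a saturated chain carbon. It is therefore the same kind of change, not the same change.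

The step from compound 3 to compound 4 is expected to be a 2.1-fold lower number from compound 3 to compound 4 (0.31 log units; beyond the scatter), roughly in line with a 2.1-fold lower number from compound 1 to compound 2 (0.32 log units; beyond the scatter). This expectation rests on a single earlier instance on a different core, so the range is kept wide. Compound 4 is estimated at 14000 nM in this assay, expected to fall between 7000 nM and 30000 nM.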

Compound 4, half-maximal inhibitory concentration: 23800 nM
Compound 4: the middle estimate sits 1.7-fold (0.23 log units) below what was measured, and the stated range covers the measured number.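

Moving the group from 4-(trifluoromethyl)phenyl to 3-(trifluoromethyl)phenyl on a sulfonyl sulfur gave a 1.2-fold lower number from compound 3 to compound 4 (0.08 log units; within the scatter) in this assay, so on this core the change has no effect that can be told apart from ordinary variation between repeated measurements. Set beside the earlier step, this result gives no firm sign that the two cores respond differently to the change: the same change on two cores in this assay, a 2.1-fold lower number (0.32 log units; beyond the scatter) from compound 1 to compound 2 and a 1.2-fold lower number (0.08 log units; within the scatter) from compound 3 to compound 4, 1.7-fold (0.23 log units) apart, within the scatter of two such steps. Within the data shown here, that agreement does not prove that the change carries over, as only two pairs are available, one step lies beyond the scatter and the other within it, and neither a small gain shared by both cores nor a real dependence on the core can be established from them.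

All four compounds shown carry a trifluoromethyl group on the ring, so it remains open whether a nitrile or a chlorine atom in its place would give a similar result on either core. Going by these compounds, it also remains open whether the step would look the same with an amine in place of the hydroxyl group on the chain.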